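Fluorine on the aromatic ring of a dimethoxy analogue

This account rests on a few compounds, and the source may have more. Where it says the series, first, only, none or still open, it means among the compounds named here.

Compound 1 `C=CC[C@H]1C[C@]2([C@@H](C)Cc3ccc(OC)c(OC)c3)OCOC2=CC1=O` is the starting point; in a functional assay on M14 cells (Homo sapiens) for antiproliferative activity, with a stated time of 72 h (on this read-out higher numbers stand for weaker inhibition and lower numbers for stronger inhibition), compound 1 gives 110 nM. Compound 2 `C=CC[C@H]1C[C@]2([C@@H](C)Cc3ccc(OC)cc3)OCOC2=CC1=O` has a different core, and the two cores differ by methoxy in place of hydrogen on an aromatic carbon; in this assay compound 2 gives 20 nM. Compound 3 `C=CC[C@H]1C[C@]2([C@@H](C)Cc3ccc(OC)c(F)c3)OCOC2=CC1=O` carries the change fluoro in place of hydrogen on an aromatic carbon on the core of compound 2, and in this assay compound 3 gives 8 nM, which is a 2.5-fold lower number from compound 2 to compound 3 (0.40 log units; beyond the scatter).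

Compound 4 `C=CC[C@H]1C[C@]2([C@@H](C)Cc3cc(OC)c(OC)cc3F)OCOC2=CC1=O` is not yet measured. It differs from compound 1 by fluoro in place of hydrogen on an aromatic carbon. This is the same kind of change as from compound 2 to compound 3, but the surroundings differ: there the fluoro is ortho to a methoxy group and meta to a large group, here it is ortho to a large group, meta to a methoxy group and para to a methoxy group. A step of similar size is expected, a 2.2-fold lower number from compound 1 to compound 4 (0.34 log units; beyond the scatter), because the same kind of change gave a 2.5-fold lower number from compound 2 to compound 3 (0.40 log units; beyond the scatter), tempered by the different place. Compound 4 is therefore estimated at 50 nM, within 20 nM to 150 nM.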

Compound 4, half-maximal inhibitory concentration: 14 nM
Compound 4: middle estimate off by 3.6-fold (0.55 log units), on the high side; the measured number lies below the stated range.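

In this assay, placing fluoro on the aromatic ring of compound 1 gives a 7.9-fold lower number from compound 1 to compound 4 (0.90 log units; beyond the scatter), so the number falls on this core as it did on the core of compound 2. The direction of the change carries over between these two cores, but its size does not, and the gap is larger than repeated measurements would be expected to produce: the same change on two cores in this assay, a 2.5-fold lower number (0.40 log units; beyond the scatter) from compound 2 to compound 3 and a 7.9-fold lower number (0.90 log units; beyond the scatter) from compound 1 to compound 4, 3.1-fold (0.50 log units) apart, beyond the scatter of two such steps. This does not show why the sizes differ: the fluoro stands in a different place on the ring in each pair and the two cores also differ, so these two pairs cannot separate the effect of place from that of core.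

Among these compounds, it remains open whether fluoro placed ortho to the large group on the core of compound 2 would give a step like the one seen on compound 1. Also open, going by these compounds, is whether a chloro group or a nitrile at the same ring carbon would follow the fluoro compounds.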